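Swapping Chloro for Methoxy on a Shared Core

The source may report more compounds than this note shows. Statements on the series, on what has been measured and on what is new or still open speak of the compounds shown alone.

Of the compounds shown here, three of one series have been measured in a physicochemical assay for lipophilicity; on this read-out higher numbers stand for higher lipophilicity and lower numbers for lower lipophilicity. Compound 1 `COc1c(OC)c(OC(=O)C(C)(C)C)c2c(Cl)cccc2c1OC(=O)C(C)(C)C` carries a chloro group and in this assay gives 6.1. Compound 2 `COc1c(OC)c(OC(=O)C(C)(C)C)c2cc(Cl)ccc2c1OC(=O)C(C)(C)C` is built from the same atoms joined differently; how its core differs from that of compound 1 is not broken down here. In this assay compound 2 gives 6.6, the highest of the three numbers. Compound 3 `COc1c(OC)c(OC(=O)C(C)(C)C)c2c(OC)cccc2c1OC(=O)C(C)(C)C` is compound 1 with methoxy in place of chloro on an aromatic carbon, and in this assay compound 3 gives 5.6. That single exchange produced a number 0.50 log units lower from compound 1 to compound 3 (beyond the scatter).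

Compound 4 `COc1ccc2c(OC(=O)C(C)(C)C)c(OC)c(OC)c(OC(=O)C(C)(C)C)c2c1` has not yet been measured. It relates to compound 2 as compound 3 relates to compound 1, through the same kind of change, methoxy in place of chloro on an aromatic carbon. The surroundings are not identical, though: in compound 3 the new group sits ortho to a fused ring and meta to a fused ring, whereas in compound 4 it sits meta to a fused ring and para to a fused ring. Among the compounds with values here, with only one earlier example of this exchange, the expectation rests on it alone. Because that earlier exchange gave a number 0.50 log units lower from compound 1 to compound 3 (beyond the scatter), compound 4 is expected to move by about a number 0.50 log units lower from compound 2 to compound 4 (beyond the scatter) in this assay. On that basis compound 4 is estimated at 6.1, most likely between 5.7 and 6.5.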

Compound 4, partition coefficient: 5.4
Estimate against measurement, compound 4: 0.70 log units above; measured number outside the range, below it.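

In this assay, putting methoxy in place of chloro gives a number 1.20 log units lower from compound 2 to compound 4 (beyond the scatter) and, on the core of compound 1, gives a number 0.50 log units lower from compound 1 to compound 3 (beyond the scatter); the number falls on both cores, but the step is large in the new pair and modest in the earlier one. Within the data shown here, this shows that, in these two pairs, the direction of the exchange carried over from one core to the other while its size did not, so a step read on one core could not be applied unchanged to the other; with only two pairs, it shows no general rule for the series. The exchange also sits in a different place in each pair, meta to a fused ring and para to a fused ring in compound 4, but nothing available here explains why the two steps differ in size, and no supporting measurement bears on the result.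

The compounds shown leave open how an amine, a carboxylic acid or a longer chain in place of chloro would read in this assay on either core. They also leave open whether such groups would repeat the uneven steps seen with methoxy or would give similar steps on both cores.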